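The compounds below may be only part of what the source reports. "The series", "measured", "known", "first", "only" and "open" are said of these compounds alone.

Measured in a functional assay on PC-3 cells (Homo sapiens) for antiproliferative activity; on this read-out higher numbers stand for weaker inhibition of growth and lower numbers for stronger inhibition of growth:
Compound 1 `c1ccc(-c2cc(-c3ccsc3)cc(-c3cccnc3)n2)nc1`: 0.054 ug/mL
Compound 2 `c1ccc(-c2cc(-c3ccco3)cc(-c3ccccn3)n2)nc1`: 0.0025 ug/mL
Compound 3 `c1ccc(-c2cc(-c3cccs3)cc(-c3ccccn3)n2)nc1`: 0.0021 ug/mL

Compound 3, at 0.0021 ug/mL, lies at the low end of these numbers, within the scatter of compound 2, while compound 1 stands clearly higher at 0.054 ug/mL. The next compound to be tested in this assay is compound 4 `c1ccc(-c2cc(-c3cccs3)cc(-c3cccnc3)n2)nc1`, which puts pyridin-3-yl in place of pyridin-2-yl on an aromatic carbon of compound 3: pyridin-3-yl in place of pyridin-2-yl on an aromatic carbon.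

Within the data shown here, no measured step isolates this exchange. Among the measured compounds shown here, the only measured step, a 1.2-fold lower number from compound 2 to compound 3 (0.08 log units; within the scatter), concerns thiophen-2-yl and furan-2-yl and stays within the scatter, so it offers little reason to think the thiophen-2-yl of compound 4 matters much. Compound 1 is the nearest guide, since it also carries pyridin-3-yl, although its thiophene ring is joined differently. Its value of 0.054 ug/mL therefore suggests a step beyond the scatter towards a higher number in this assay, which weaker inhibition of growth would mean. The expected move is a 14-fold higher number from compound 3 to compound 4 (1.15 log units; beyond the scatter), an estimate that stops slightly short of compound 1. Compound 4 is expected at 0.03 ug/mL, with an estimated range from 0.007 ug/mL to 0.12 ug/mL.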

Compound 4, concentration for 50% growth inhibition: 0.031 ug/mL
For compound 4 the middle estimate is 1.0-fold (0.01 log units) below the measured one, within the range that was stated.
By their numbers in this assay, from the lowest: compounds 3 and 2 (each within the scatter of the next); then compounds 4 and 1 (each within the scatter of the next).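

In this assay, the exchange of pyridin-2-yl for pyridin-3-yl at this place, next to the ring nitrogen of the shared core, gives a 15-fold higher number from compound 3 to compound 4 (1.17 log units; beyond the scatter) and so is a large step between two compounds with the same atoms joined differently. The thiophene attachment counts for far less here, since a 1.7-fold lower number from compound 1 to compound 4 (0.24 log units; within the scatter) is a step that stays within the scatter, as does a 1.2-fold lower number from compound 2 to compound 3 (0.08 log units; within the scatter) for the exchange of furan-2-yl and thiophen-2-yl; among the compounds shown, only the pyridine exchange moves the number beyond the scatter. Nothing available accounts for the size of this step.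

On these data alone, whether pyridin-4-yl or a plain phenyl at this place would stay near compound 3 or near compound 4 remains open, as does the effect of an amine or a methoxy group on the pyridin-3-yl ring. As far as these compounds go, it is also open whether the same exchange costs as much with furan-2-yl in place of the thiophene, or at the remaining pyridin-2-yl group of compound 4.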